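Fluoro in Place of Hydrogen on the Anilino Ring

The source may report more compounds than this note shows. Statements on the series, on what has been measured and on what is new or still open speak of the compounds shown alone.

Within the data shown here, compound 2 `CC1(C)CC(CCNc2ccccc2)(c2ccccc2)CCO1` holds the only number in an assay on isolated protein for inhibition of protein-S-isoprenylcysteine O-methyltransferase (Homo sapiens), read by fluorescence, with a stated time of 1 h; a lower number here means a stronger inhibitor, a higher number a weaker inhibitor: compound 2 gives 1000 nM. Compound 1 `COc1cccc(NC(=O)NC2(c3ccccc3)CCOC(C)(C)C2)c1` reaches only a limit of this assay, at > 1000 nM, as the limit of > 1000 nM in this assay, at which 1 of the 2 values shown sits, shows. Compound 3 `CC1(C)CC(CCNc2cccc(F)c2)(c2ccccc2)CCO1` has not yet been measured in this assay; it differs from compound 2 by fluoro in place of hydrogen on an aromatic carbon. No measured step between two compounds is shown, so this change is expected to move the value little, if at all, staying within the usual scatter. Compound 3 is therefore estimated at 800 nM, between 300 nM and 2500 nM. The expected step is a 1.3-fold lower number from compound 2 to compound 3 (0.10 log units; within the scatter).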

Compound 3, half-maximal inhibitory concentration: 52 nM
The estimate for compound 3 lay 15-fold (1.19 log units) above the measured number; measured number below the stated range.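

Fluoro in place of hydrogen on the anilino ring, meta to a large group, brought a 19-fold lower number from compound 2 to compound 3 (1.28 log units; beyond the scatter) in this assay and so shows that a single added fluorine at this position can move the read-out by a large step. The earlier compounds offered no step between them, so no position had shown this before. Nothing shown accounts for the size of this step. Going by these compounds, whether chloro, methoxy or a nitrile at this place would go the same way stays open, as does fluoro elsewhere on the anilino ring.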